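A Fluoro Swap on a Weakly Cytotoxic Compound

This account rests on a few compounds, and the source may have more. Where it says the series, first, only, none or still open, it means among the compounds named here.

Going by the values given here, in a functional assay on MCF7 cells (Homo sapiens) for cytotoxicity, read by MTT assay, with a stated time of 72 h (a lower number here means a stronger inhibitor, a higher number a weaker inhibitor), compound 2 `CNC(=O)c1cc(Oc2ccc(NC(=O)c3nccc(-c4ccc(C)cc4)n3)cc2)ccn1` gives 44300 nM, the only true number available so far. Compound 1 `CNC(=O)c1cc(Oc2ccc(NC(=O)c3nccc(-c4ccc(OC)cc4)n3)cc2F)ccn1` returns > 100000 nM, which is a limit of the assay and not a number. Compound 3 `CNC(=O)c1cc(Oc2ccc(NC(=O)c3nccc(-c4ccc(C)cc4)n3)cc2F)ccn1` differs from compound 2 by a single change: fluoro in place of hydrogen on an aromatic carbon. Among the compounds with values here, no measured pair shows this change, so no shift beyond the usual scatter is expected. The expected size of the move is a 1.2-fold higher number from compound 2 to compound 3 (0.09 log units; within the scatter). For compound 3 the estimated value is 55000 nM, with an expected range from 22000 nM to 100000 nM.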

Compound 3, half-maximal inhibitory concentration: 69200 nM
Estimate against measurement, compound 3: 1.3-fold (0.10 log units) below; measured number inside the range.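

Fluoro in place of hydrogen on this aromatic carbon, ortho to a (2-(methylcarbamoyl)pyridin-4-yl)oxy group, now has a real reading in this assay: the change gives a 1.6-fold higher number from compound 2 to compound 3 (0.19 log units; within the scatter) and so moves nothing that can be told from scatter. Methyl in place of methoxy gives an at least 1.4-fold lower number from compound 1 to compound 3 (0.15 log units; that floor lies within the scatter) and this floor does not separate the two groups. Compound 1 stands at a limit and has no true number: the limit of > 100000 nM in this assay, at which 1 of the 3 values shown sits.

Going by these compounds, whether chloro or an amine on this same carbon would shift the number beyond the scatter remains open. So does whether fluoro behaves the same way on a far stronger compound.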